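Notes on the aryl substituent at the aromatic nitrogen

A few compounds are considered here, and "the series" means these few. Any claim that something is new, unique, unknown or untested is made for them only; others in the source may bear on it.

Within the data shown here, compound 2 `COc1ccc(-n2nc(C(=O)Nc3ccc(Oc4ccnc5cc(OCCCN6CCCCC6)c(OC)cc45)c(F)c3)c(C)cc2=O)cc1` is measured in a functional assay on A549 cells (Homo sapiens) for inhibition, read by MTT assay, with a stated time of 72 h (a higher number here means a weaker inhibitor, a lower number a stronger inhibitor), at 1500 nM; this is the highest of the two numbers so far. Its nearest neighbour is compound 1 `COc1cc2c(Oc3ccc(NC(=O)c4nn(-c5cccc(F)c5)c(=O)cc4C)cc3F)ccnc2cc1OCCCN1CCCCC1`, which in this assay gives 250 nM. The step of a 6.0-fold higher number from compound 1 to compound 2 (0.78 log units; beyond the scatter) covers the 4-methoxyphenyl in place of 3-fluorophenyl on an aromatic nitrogen. Compound 3 `COc1cc2c(Oc3ccc(NC(=O)c4nn(-c5ccc(Cl)cc5)c(=O)cc4C)cc3F)ccnc2cc1OCCCN1CCCCC1` differs from compound 2 by chloro in place of methoxy on an aromatic carbon, read one bond further out as 4-methoxyphenyl to 4-chlorophenyl; the group that enters is a halogen, as in compound 1. Among the measured compounds shown here, only one measured step bears on this change, and it runs the other way: the number rose from the fluoro-bearing compound 1 to the methoxy-bearing compound 2. The step of a 3.8-fold lower number from compound 2 to compound 3 (0.57 log units; beyond the scatter) is therefore expected to lower the number, though chloro is not the fluoro of compound 1, so less than a full return is assumed. Compound 3 is estimated at 400 nM in this assay, with a range of 150 nM to 1200 nM.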

Compound 3, half-maximal inhibitory concentration: 320 nM
The estimate for compound 3 lay 1.3-fold (0.10 log units) above the measured number, and the stated range covers the measured number.
By their numbers in this assay, from the lowest: compounds 1 and 3 (each within the scatter of the next); then compound 2.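

In this assay, the exchange of methoxy for chloro at this place gives a 4.7-fold lower number from compound 2 to compound 3 (0.67 log units; beyond the scatter), so the higher number of compound 2 goes with the methoxy group and not with any substituent on this carbon. The aryl group on the aromatic nitrogen also tolerates more than one halogen pattern: 4-chlorophenyl in place of 3-fluorophenyl gives a 1.3-fold higher number from compound 1 to compound 3 (0.11 log units; within the scatter), which leaves compound 1 and compound 3 not separated, with compound 2 alone apart from them. Nothing on hand bears on what lies behind these differences.

Still open, as far as these compounds go, is whether the number follows the halogens or the methoxy group when an amine, such as dimethylamino, or a carboxylic acid stands at this carbon. Also open, from the compounds shown here alone, is how the unsubstituted phenyl group compares with the halogen-bearing aryl groups of compound 1 and compound 3.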